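Dropping One Fluorine From a Weak Antiproliferative Lead

The source may report more compounds than this note shows. Statements on the series, on what has been measured and on what is new or still open speak of the compounds shown alone.

Measured compounds:
compound 1, `CCOC(=O)CN(Cc1cc(F)cc(F)c1)c1ccc2c(c1)OC(C)(COc1ccc(C#N)cc1)CN2C`, > 100000 nM in a functional assay on HeLa cells (Homo sapiens) for antiproliferative activity, read by cell counting, with a stated time of 4 days; a lower number here means a stronger inhibitor, a higher number a weaker inhibitor
compound 2, `CCOC(=O)C(=O)N(Cc1ccccc1)c1ccc2c(c1)OC(C)(CO)CN2C`, > 100000 nM
compound 3, `CCOC(=O)CN(Cc1cc(F)cc(F)c1)c1ccc2c(c1)N(C)CC(C)(COc1ccc(C(=N)N)cc1)O2`, 4500 nM

The value given for compound 1 is a limit of this assay, not a number. The value given for compound 2 is likewise a limit. Going by the values given here, compound 3 is therefore the only compound of the three with a number in this assay; the other two sit at the limit of > 100000 nM in this assay, at which 2 of the 3 values shown sit, so compound 3 stands alone and nothing can be said of a step between it and the others.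

Compound 4, `CCOC(=O)CN(Cc1cccc(F)c1)c1ccc2c(c1)N(C)CC(C)(COc1ccc(C(=N)N)cc1)O2`, has not yet been measured. It differs from compound 3 in a single place: hydrogen in place of fluoro on an aromatic carbon. Cut one bond further out, this reads as 3,5-difluorobenzyl going to 3-fluorobenzyl.

Among the compounds with values here, no step between two measured compounds is known here, so there is no measured basis for the size of this change. Loss of a single fluoro is expected to make only a small difference, if any beyond the scatter. Compound 4 is estimated at 6000 nM, within 2000 nM to 20000 nM, which means an expected step of a 1.3-fold higher number from compound 3 to compound 4 (0.12 log units; within the scatter).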

Compound 4, half-maximal inhibitory concentration: 4600 nM
Compound 4: the middle estimate sits 1.3-fold (0.12 log units) above what was measured; the range from low to high includes it.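

Going by these compounds alone, replacing one fluoro with hydrogen, the change from 3,5-difluorobenzyl to 3-fluorobenzyl, gives a 1.0-fold higher number from compound 3 to compound 4 (0.01 log units; within the scatter) in this assay, and this is the first step between two measured compounds. At this place on the ring, then, a fluoro and a hydrogen cannot be told apart in this assay while the other fluoro stays in place. Nothing in the data shown explains this match.

The compounds shown leave open whether the remaining fluoro of the 3-fluorobenzyl group could also give way to hydrogen, and how a larger group at this place, such as methoxy or an amine, would read in the same assay. Also open, on these data alone, is how a carboxylic acid in place of the ethyl ester would compare with compound 4.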